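The source may report more compounds than this note shows. Statements on the series, on what has been measured and on what is new or still open speak of the compounds shown alone.

Measured so far:
compound 1 `Oc1ccc(CNc2cc(C(F)(F)F)cc3[nH]ncc23)cc1` — 2550 nM
compound 2 `O=[N+]([O-])c1ccc(CNc2cc(C(F)(F)F)cc3[nH]ncc23)cc1` — > 100000 nM
compound 3 `O=[N+]([O-])c1cc(Br)c(F)cc1CNc1cc(C(F)(F)F)cc2[nH]ncc12` — 1460 nM

In an assay for inhibition of Tryptophan 2,3-dioxygenase (Homo sapiens), with stated times of 10 min and 60 min (a higher number here means a weaker inhibitor, a lower number a stronger inhibitor), compound 1 gives 2550 nM and stands as the higher of the two numbers recorded; compound 3 is the nearest at 1460 nM, a gap within the scatter, so no order between the two is claimed. Compound 2 gives no number but only a limit, (the limit of > 100000 nM in this assay, at which 1 of the 3 values shown sits).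

Within the data shown here, the single measured step is an at least 39-fold higher number from compound 1 to compound 2 (1.59 log units; beyond the scatter), nitro in place of hydroxy on an aromatic carbon. Among the measured compounds shown here, that is the only evidence on what follows when the hydroxy leaves.

Compound 4 `FC(F)(F)c1cc(NCc2cccc(Br)c2)c2cn[nH]c2c1` differs from compound 1 by 3-bromophenyl in place of 4-hydroxyphenyl on a saturated chain carbon bound to a nitrogen on an aromatic ring. The hydroxy leaves here too, so the step to compound 2 bears on it, though what enters is bromine rather than nitro. Compound 3, which carries a bromine beside its nitro and fluorine, gives 1460 nM, close to compound 1, so a bromine on the benzyl ring is at least not ruinous there. Compound 4 is therefore expected to lose some potency, by a 2.7-fold higher number from compound 1 to compound 4 (0.44 log units; beyond the scatter), clearly less than the step to compound 2. The estimate for compound 4 is 7000 nM, with a range of 2000 nM to 30000 nM.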

Compound 4, half-maximal inhibitory concentration: 19100 nM
Compound 4: the middle estimate sits 2.7-fold (0.44 log units) below what was measured; low and high end bracket the measured number.
By their numbers in this assay, from the lowest: compounds 3 and 1 (each within the scatter of the next); then compound 4. At a limit, above all of these: compound 2.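

In this assay, 3-bromophenyl in place of 4-hydroxyphenyl on the saturated chain carbon gives a 7.5-fold higher number from compound 1 to compound 4 (0.87 log units; beyond the scatter), a modest loss at this position. The hydroxy, with its hydrogen-bond donor and acceptor, is therefore not indispensable for a measurable number, since compound 4 still gives a value rather than a limit. The step changes the group and where its substituent sits together, and nothing measured here gives a cause for it.

Left open is how an unsubstituted phenyl would stand against compound 1, and so how much of the step belongs to the loss of hydroxy and how much to the bromine. Also open, from the compounds shown here alone, is how an amine or a carboxylic acid on this ring, or a longer chain at this carbon, would read.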